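Morpholin-4-yl in Place of Thiomorpholin-4-yl: An Expected Value

The compounds below may be only part of what the source reports. "The series", "measured", "known", "first", "only" and "open" are said of these compounds alone.

Compound 1, `N/C(=N\NC(=S)N1CCOCC1)c1ccccn1`, gives 680 nM in a functional assay on A-375 cells (Homo sapiens) for cytotoxicity, read by MTT assay, with a stated time of 72 h; on this read-out lower numbers stand for stronger inhibition and higher numbers for weaker inhibition. Compound 2, `Cc1cccc(/C(N)=N/NC(=S)N2CCSCC2)n1`, gives 1400 nM in this assay.

Compound 2 holds the higher of these two numbers; compound 1 sits lower by a gap beyond the scatter. Compound 3, `Cc1cccc(/C(N)=N/NC(=S)N2CCOCC2)n1`, differs from compound 2 in one place: morpholin-4-yl in place of thiomorpholin-4-yl on a thiocarbonyl carbon. Going by the values given here, no measured pair differs by this change alone, so its size is unknown. In this assay the step is expected to stay within the scatter, leaning if anything toward a lower number. Compound 3 is estimated at 1000 nM, between 450 nM and 2200 nM. The expected step is a 1.4-fold lower number from compound 2 to compound 3 (0.15 log units; within the scatter).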

Compound 3, half-maximal inhibitory concentration: 14000 nM
Compound 3: the middle estimate sits 14-fold (1.15 log units) below what was measured, and the stated range ends below it.
By their numbers in this assay, from the lowest: compound 1; then compound 2; then compound 3.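

Morpholin-4-yl in place of thiomorpholin-4-yl on a thiocarbonyl carbon proves to be no neutral exchange on this core: it brings a 10-fold higher number from compound 2 to compound 3 (1.00 log units; beyond the scatter) in this assay. With morpholin-4-yl held fixed, methyl in place of hydrogen on an aromatic carbon brings a 21-fold higher number from compound 1 to compound 3 (1.31 log units; beyond the scatter) in this assay, so this read-out responds to a change in either place.

Going by these compounds, what a piperazin-1-yl or a dimethylamino group would give on the thiocarbonyl carbon remains open, as does the size of the morpholin-4-yl step on the core of compound 1. No available measurement explains either step.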